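Working notes: compound 2 to compound 4

The source may report more compounds than this note shows. Statements on the series, on what has been measured and on what is new or still open speak of the compounds shown alone.

Measured so far:
- compound 1, `COc1cc(/C=C/C(=O)c2cccc(-n3cc(-c4ccccc4)[nH]c3=O)c2)cc(OC)c1OC`, gives 1230 nM
- compound 2, `COc1cc(/C=C/C(=O)c2cccc(-n3cc(-c4ccccc4)[nH]c3=O)c2)ccc1O`, gives 2290 nM
- compound 3, `O=C(/C=C/c1cccc(O)c1)c1cccc(-n2cc(-c3ccc(Cl)cc3)[nH]c2=O)c1`, gives 1560 nM

All three numbers come from a functional assay on OVCAR-3 cells (Homo sapiens) for inhibition; a higher number here means a weaker inhibitor of growth, a lower number a stronger inhibitor of growth. Compound 2 stands at the highest of the three numbers, but its gap to compound 3 and its gap to compound 1 both lie within the scatter, so no order among the three is claimed and none is called the weaker or stronger.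

Compound 4, `COc1ccc(-c2cn(-c3cccc(C(=O)/C=C/c4ccc(O)c(OC)c4)c3)c(=O)[nH]2)cc1`, is not yet measured in this assay. It differs from compound 2 in one place: methoxy in place of hydrogen on an aromatic carbon. Cut one bond further out, the change reads phenyl to 4-methoxyphenyl. For the measured compounds named here, no two measured compounds differ in only one place, so there is no measured step of this kind to lean on; compound 3 carries a different group on that ring along with other changes, and its number sits within the scatter of compound 2.

With nothing in the data pointing either way, the step from compound 2 to compound 4 is expected to be small, a 1.1-fold lower number from compound 2 to compound 4 (0.06 log units; within the scatter), within the scatter rather than beyond it. Compound 4 is therefore estimated at 2000 nM, with a range from 800 nM to 5000 nM.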

Compound 4, concentration for 50% growth inhibition: 2700 nM
Compound 4: the middle estimate sits 1.4-fold (0.13 log units) below what was measured, within the range that was stated.
By their numbers in this assay, from the lowest: compounds 1, 3, 2 and 4 (each within the scatter of the next, the first and the last beyond it).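

In this assay, the change from phenyl to 4-methoxyphenyl reads a 1.2-fold higher number from compound 2 to compound 4 (0.07 log units; within the scatter), so methoxy in place of hydrogen on this aromatic carbon, para to a large group, gives no step beyond the scatter. For the compounds shown here, this is the only comparison between compounds that differ in one place, and it gives this position its first direct reading, which the earlier compounds could not provide. The reading covers methoxy on the background of compound 2 only, and no measurement available here bears on an explanation for it.

Still open, from the compounds shown here alone, is whether an amine, a carboxylic acid or a longer chain such as butoxy in place of the same hydrogen would also stay within the scatter or produce a clear step in either direction. Also open, going by these compounds, is whether methoxy at this position would give a similar step on the background of compound 1, or of compound 3 with the chloro group replaced, since a single step on one background cannot show how far the result carries across the series.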